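A few compounds are considered here, and "the series" means these few. Any claim that something is new, unique, unknown or untested is made for them only; others in the source may bear on it.

Measured in a functional assay on PC-9 cells (Homo sapiens) for inhibition, read by MTT assay, with a stated time of 72 h; on this read-out higher numbers stand for weaker inhibition and lower numbers for stronger inhibition:

- compound 1 `Cc1cc(Nc2cc(-c3ccccc3)[nH]n2)n2nc(SCc3cccc(Br)c3)nc2n1`: 8900 nM
- compound 3 `Cc1cc(Nc2ccn(Cc3ccc(C(F)(F)F)cc3)n2)n2nc(SCc3ccc(Br)cc3)nc2n1`: 5580 nM
- compound 2 `CCCCCc1c(C)nc2nc(SCc3ccc(Cl)cc3)nn2c1Nc1cc(-c2ccccc2)[nH]n1`: reported only as a limit of the assay, > 50000 nM

Compound 1 holds the higher of the two numbers in this assay, but compound 3 lies close to it and the gap is within the scatter, so no order between the two is claimed. Compound 2 stands at the limit of > 50000 nM in this assay, at which 1 of the 3 values shown sits.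

Compound 4 `COc1ccc(CSc2nc3nc(C)cc(Nc4cc(-c5ccccc5)[nH]n4)n3n2)cc1` has not yet been measured in this assay. It differs from compound 1 in one place: 4-methoxyphenyl in place of 3-bromophenyl on a saturated chain carbon bound to a sulfur. Among the compounds with values here, no pair of measured compounds isolates this change, so nothing anchors its size. The expected step from compound 1 to compound 4 is a 1.1-fold lower number from compound 1 to compound 4 (0.05 log units; within the scatter), small and plausibly within the scatter. Compound 4 is estimated at 8000 nM, with a range from 2500 nM to 30000 nM.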

Compound 4, half-maximal inhibitory concentration: 8110 nM
Compound 4: middle estimate off by 1.0-fold (0.01 log units), on the low side, within the range that was stated.
By their numbers in this assay, from the lowest: compounds 3, 4 and 1 (each within the scatter of the next). At a limit, above all of these: compound 2.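

In this assay the first step readable at this position is a 1.1-fold lower number from compound 1 to compound 4 (0.04 log units; within the scatter), so on a saturated chain carbon bound to a sulfur, 3-bromophenyl and 4-methoxyphenyl cannot be told apart. The entering group's added oxygen and hydrogen-bond acceptor bring no separable difference in this read-out. Nothing measured here gives a cause for this step.

This single step does not separate the kind of substituent from its place on the phenyl ring. An amine or a carboxylic acid in place of the bromine or methoxy group remains an open case.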